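The source may hold more compounds than are shown below. What is called first, only, known or untested is meant among the compounds shown, and "the series" means these compounds.

Of the compounds shown here, three of a shared core have been measured in a functional assay on HCT-116 cells (Homo sapiens) for positive allosteric modulation, read by MTT assay, with stated times of 24 h and 48 h, tested at 2.5 uM; on this read-out higher numbers stand for more inhibition of growth at the one concentration tested and lower numbers for less inhibition of growth. Compound 1 `N#Cc1ccc(-c2cnc3[nH]cc(-c4nnc(-c5ccc(F)cc5)o4)c(=O)c3c2)cc1` gives 25.6%, compound 2 `CS(=O)(=O)c1ccc(-c2cnc3[nH]cc(-c4nnc(-c5ccccc5)o4)c(=O)c3c2)cc1` gives 27.2%, and compound 3 `O=c1c(-c2nnc(-c3ccc(F)cc3)o2)c[nH]c2ncc(-c3cccnc3)cc12` gives 20.1%. The number for compound 2 sits at the top of the three, yet its gaps to compound 1 and to compound 3 both lie within the scatter. For the measured compounds named here, the one measured step, a number 5.5 percentage points lower from compound 1 to compound 3 (within the scatter), also stays within the scatter. Compound 4 `CS(=O)(=O)c1ccc(-c2cnc3[nH]cc(-c4nnc(-c5ccc(Cl)cc5)o4)c(=O)c3c2)cc1` differs from compound 2 by chloro in place of hydrogen on an aromatic carbon. Going by the values given here, no measured step bears on this change, so the expectation is a step of a number 0.8 percentage points higher from compound 2 to compound 4 (within the scatter) in this assay, none beyond the scatter. Compound 4 is therefore expected to give about 28%, between 18% and 38%.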

Compound 4, percent growth inhibition at one concentration: 24.9%
Estimate against measurement, compound 4: 3.1 percentage points above; the range from low to high includes it.
By their numbers in this assay, from the lowest: compounds 3, 4, 1 and 2 (each within the scatter of the next).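

Chloro in place of hydrogen, para to a large group on the six-membered aromatic ring of carbon only, gives a number 2.3 percentage points lower from compound 2 to compound 4 (within the scatter) in this assay as the first measured step at this place. At the one concentration tested, this position therefore tolerates the phenyl to 4-chlorophenyl change without a step beyond the scatter. Nothing measured here bears on the reason for this result. The compounds shown leave open whether an amine or a carboxylic acid at this position would give a step beyond the scatter.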